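Aminothiazolyl replacement at the aryl ether of compound 3

The compounds below may be only part of what the source reports. "The series", "measured", "known", "first", "only" and "open" are said of these compounds alone.

Measured so far:
compound 1 `C#CCNCC(O)COc1ccc2c(C)c(Cc3ccccc3)c(=O)oc2c1` 95500 nM
compound 2 `Cc1c(Cc2ccccc2)c(=O)oc2cc(OCC(CN3CCC(C(N)=O)CC3)Oc3ccc(F)cc3)ccc12` 66400 nM
compound 3 `COc1ccc(OC(COc2ccc3c(C)c(Cc4ccccc4)c(=O)oc3c2)CN2CCC(C(N)=O)CC2)cc1` 94900 nM

In an ADME assay on A549 cells (Homo sapiens) for cytotoxicity, read by CellTiter-Glo (on this read-out higher numbers stand for lower toxicity in this test and lower numbers for higher toxicity in this test), compound 3 gives the second highest of the three numbers, and all three lie within the scatter of one another. Compound 4 `Cc1c(Cc2ccccc2)c(=O)oc2cc(OCC(CN3CCC(C(N)=O)CC3)Oc3ccc(-c4ncc(N)s4)cc3)ccc12` is not yet measured. The change from compound 3 is 5-amino-1,3-thiazol-2-yl in place of methoxy on an aromatic carbon. Going by the values given here, the only measured step at the same position, a 1.4-fold higher number from compound 2 to compound 3 (0.16 log units; within the scatter), stayed within the scatter, and nothing else in the set bears on a group of this size at that carbon. A step of no more than the scatter is therefore expected, a 1.2-fold lower number from compound 3 to compound 4 (0.07 log units; within the scatter). Compound 4 is estimated at 80000 nM in this assay, with a range of 30000 nM to 200000 nM.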

Compound 4, half-maximal cytotoxic concentration: > 100000 nM
Compound 4 ended at the assay's limit; the forecaster's own chance of this, stated with the estimate: 15%; middle value at least 1.2-fold (0.09 log units) away from the limit.
By their numbers in this assay, from the lowest: compounds 2, 3 and 1 (each within the scatter of the next). At a limit, above all of these: compound 4.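

In this assay compound 4 gives > 100000 nM, which is a limit of the assay and not a number: the limit of > 100000 nM in this assay, at which 1 of the 4 values shown sits. The steps of an at least 1.0-fold higher number from compound 3 to compound 4 (0.02 log units; that floor lies within the scatter) and an at least 1.5-fold higher number from compound 2 to compound 4 (0.17 log units; that floor lies within the scatter) are floors only, so their true size cannot be read. Going by these compounds alone, still, this carbon, so far seen only with methoxy and fluoro, also takes a five-membered aromatic ring, 5-amino-1,3-thiazol-2-yl, with no sign of higher toxicity in this test.

Open, as far as these compounds go, is how an aminomethyl group or a carboxylic acid at this carbon would read. Also open, from the compounds shown here alone, is whether the thiazole without its amino group would stay at the limit.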